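This account rests on a few compounds, and the source may have more. Where it says the series, first, only, none or still open, it means among the compounds named here.

Three compounds share one core and differ only in the group on the sulfonamide nitrogen. Compound 1, `O=S(=O)(CSc1nnc(Br)n1Cc1ccc(Br)c2ccccc12)Nc1ccccc1`, carries a phenyl there and gives 15800 nM in an assay on HEK293 cells for inhibition of solute carrier family 22 member 12 (Homo sapiens); on this read-out higher numbers stand for weaker inhibition and lower numbers for stronger inhibition. Compound 2, `O=S(=O)(CSc1nnc(Br)n1Cc1ccc(Br)c2ccccc12)Nc1ccc(F)nc1`, gives 1550 nM in this assay, and compound 3, `O=S(=O)(CSc1nnc(Br)n1Cc1ccc(Br)c2ccccc12)Nc1cc(Cl)cnc1Cl`, gives 2790 nM. Among these three numbers compound 3 stands second highest: the step of a 5.7-fold lower number from compound 1 to compound 3 (0.75 log units; beyond the scatter) is modest, while a 1.8-fold higher number from compound 2 to compound 3 (0.26 log units; within the scatter) stays within the scatter.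

Compound 4, `O=S(=O)(CSc1nnc(Br)n1Cc1ccc(Br)c2ccccc12)Nc1ccc(Br)nc1Br`, differs from compound 3 in that (2,6-dibromopyridin-3-yl in place of 2,5-dichloropyridin-3-yl on a sulfonamide nitrogen). Among the measured compounds shown here, two measured steps bear on this. The step of a 5.7-fold lower number from compound 1 to compound 3 (0.75 log units; beyond the scatter) shows that a halogenated pyridinyl in place of phenyl lowered the number, and the step of a 1.8-fold higher number from compound 2 to compound 3 (0.26 log units; within the scatter) shows that two differently halogenated pyridinyls stayed within the scatter of each other. For the measured compounds named here, no measured pair separates chlorine from bromine on this ring. In this assay compound 4 is therefore expected to show a 1.1-fold lower number from compound 3 to compound 4 (0.05 log units; within the scatter), no step beyond the scatter. The estimate for compound 4 in this assay is 2500 nM, with a range from 900 nM to 7000 nM.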

Compound 4, half-maximal inhibitory concentration: 5410 nM
Estimate against measurement, compound 4: 2.2-fold (0.34 log units) below; measured number inside the range.
By their numbers in this assay, from the lowest: compounds 2, 3 and 4 (each within the scatter of the next, the first and the last beyond it); then compound 1.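

In this assay, the 2,6-dibromopyridin-3-yl group cannot be told apart from the 2,5-dichloropyridin-3-yl group (with a 1.9-fold higher number from compound 3 to compound 4 (0.29 log units; within the scatter) as the step), so exchanging both the halogen and the substitution pattern gives no clear difference at this sulfonamide nitrogen. It does, however, give the first separation beyond the scatter between two halogenated pyridinyls (with a 3.5-fold higher number from compound 2 to compound 4 (0.54 log units; beyond the scatter) as the step), showing that this position can distinguish among them, while the advantage over phenyl remains (with a 2.9-fold lower number from compound 1 to compound 4 (0.47 log units; beyond the scatter) as the step). The information given here offers no explanation for these differences.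

The compounds shown leave open how much of the gap between compound 2 and compound 4 comes from the identity of the halogens and how much from their placement. They also leave open how an unsubstituted pyridin-3-yl, or a pyridinyl carrying an amine or a carboxylic acid, would behave at this position.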